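The source may hold more compounds than are shown below. What is called first, only, known or untested is meant among the compounds shown, and "the series" means these compounds.

The three measured compounds share one core and differ in the group on the amine nitrogen and in the aryl attached to the sulfone. Compound 1 `CNCC1CCCc2cc(S(=O)(=O)c3ccccc3)ccc21` gives 0.316 nM in an assay on isolated protein for displacement of a labelled ligand from 5-hydroxytryptamine receptor 6 (Homo sapiens) (a lower number here means a stronger inhibitor, a higher number a weaker inhibitor), and compound 2 `NC[C@@H]1CCCc2cc(S(=O)(=O)c3cc[nH]c3)ccc21` gives 0.316 nM in this assay. Compound 3 `CNS(=O)(=O)NC[C@@H]1CCCc2cc(S(=O)(=O)c3cccc(F)c3)ccc21` gives 1 nM in this assay, the highest of the three numbers; its gaps to compound 1 and to compound 2 both lie beyond the scatter, so compound 3 is the weakest of the three in this set.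

Compound 4 `O=S(=O)(c1cccc(F)c1)c1ccc2c(c1)CCC[C@H]2CNCCO` has not yet been measured. It differs from compound 3 in one place: 2-hydroxyethyl in place of methylsulfamoyl on an amine nitrogen. No pair among the measured compounds shows exactly this change, so its size cannot be read from a shown step. Compound 1, which carries a methyl on the amine nitrogen, gives 0.316 nM, and on that ground compound 4 is expected to move back toward the lower numbers. The step from compound 3 to compound 4 is expected to be a 2.0-fold lower number from compound 3 to compound 4 (0.30 log units; within the scatter), a decrease of modest size, beyond the scatter but not large. Compound 4 is therefore estimated at 0.5 nM, with a range from 0.16 nM to 1.6 nM.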

Compound 4, inhibition constant: 0.126 nM
Compound 4: the middle estimate sits 4.0-fold (0.60 log units) above what was measured; measured number outside the range, below it.
By their numbers in this assay, from the lowest: compound 4; then compounds 1 and 2 (each within the scatter of the next); then compound 3.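

In this assay, replacing methylsulfamoyl with 2-hydroxyethyl on the amine nitrogen gives a 7.9-fold lower number from compound 3 to compound 4 (0.90 log units; beyond the scatter). Going by these compounds alone, this is the first step in the set in which only one place changes, and it shows that the group on this nitrogen alone can move the number beyond the scatter, with the aryl on the sulfone held fixed; the entering group has no sulfur and fewer heavy atoms than the one that leaves, and compound 4 still gives 0.126 nM. The data shown offer no measurement that explains why this change lowers the number.

Going by these compounds, it remains open whether the hydroxyl of the 2-hydroxyethyl group matters or whether the loss of methylsulfamoyl accounts for the step, a question that a plain ethyl or a 2-methoxyethyl group on the same nitrogen could separate, while a longer chain such as 3-hydroxypropyl or a carboxylic acid at the chain end would probe how much this position accepts. On these data alone, it is also open whether the same change would give a step of similar size with the different aryl groups on the sulfone in compound 1 and compound 2.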